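A few compounds are considered here, and "the series" means these few. Any claim that something is new, unique, unknown or untested is made for them only; others in the source may bear on it.

Values in a functional assay on HeLa cells (Homo sapiens) for antiproliferative activity, read by MTT assay, with a stated time of 48 h; a higher number here means a weaker inhibitor of growth, a lower number a stronger inhibitor of growth:
compound 1 `COC(=O)N1N=C(c2ccccc2)CC1c1cc(OC)c(OC)c(OC)c1`: 2180 nM
compound 2 `COc1cc(C2CC(c3ccccc3)=NN2C(=O)OCc2ccccc2)cc(OC)c1OC`: > 10000 nM, a limit of the assay
compound 3 `COC(=O)N1N=C(c2ccccc2)CC1c1ccc(OC)c(OC)c1`: 5480 nM

Compound 1 has the lower of the two numeric values, and compound 3 is its nearest neighbour. Compound 4 `CCOc1cccc(C2=NN(C(=O)OC)C(c3cc(OC)c(OC)c(OC)c3)C2)c1` differs from compound 1 as follows: ethoxy in place of hydrogen on an aromatic carbon. Phenyl becomes 3-ethoxyphenyl. Going by the values given here, no measured step changes this phenyl, so the evidence is indirect. The two steps elsewhere on compound 1 are a 2.5-fold higher number from compound 1 to compound 3 (0.40 log units; beyond the scatter) and an at least 4.5-fold higher number from compound 1 to compound 2 (0.66 log units; beyond the scatter). Both raise the number. A small rise in this assay is therefore expected, possibly not beyond the scatter. The expected change is a 1.4-fold higher number from compound 1 to compound 4 (0.14 log units; within the scatter). For compound 4 the estimate is 3000 nM, with an expected range of 1000 nM to 8000 nM.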

Compound 4, concentration for 50% growth inhibition: 4970 nM
Compound 4: middle estimate off by 1.7-fold (0.22 log units), on the low side; the range from low to high includes it.
By their numbers in this assay, from the lowest: compound 1; then compounds 4 and 3 (each within the scatter of the next). At a limit, above all of these: compound 2.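

In this assay, the phenyl of compound 1 proves responsive to substitution: ethoxy on an aromatic carbon, meta to a large group, gives a 2.3-fold higher number from compound 1 to compound 4 (0.36 log units; beyond the scatter), a modest step. Going by these compounds alone, the only change read at this phenyl therefore raises the number, as do the two steps elsewhere on compound 1. No measurement shown accounts for this rise.

On these data alone, it remains open whether a hydroxyl or an amine in the same place would leave the number of compound 1 unchanged. As far as these compounds go, whether ethoxy elsewhere on this phenyl gives a similar step also remains open.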